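The source may report more compounds than this note shows. Statements on the series, on what has been measured and on what is new or still open speak of the compounds shown alone.

Working notes on the series. The read-out throughout is a functional assay on A549 cells (Homo sapiens) for antiproliferative activity, read by MTT assay, with a stated time of 48 h; on this read-out higher numbers stand for weaker inhibition and lower numbers for stronger inhibition. Two compounds have been run so far. Compound 1 `N#CC1=C(N)Oc2c(c3nc4ccccc4nc3c3ccccc23)C12C(=O)N(Cc1cnnn1-c1ccc(F)cc1)c1ccccc12` gives in this assay only a limit of the assay and not a number, > 50000 nM. Compound 2 `COc1ccc(-n2nncc2CN2C(=O)C3(C(C#N)=C(N)Oc4c(N)cc5nc6ccccc6nc5c43)c3ccccc32)cc1` likewise gives in this assay only a limit and not a number, > 50000 nM. Among the measured compounds shown here, compound 2 therefore stands at the top of the measured range together with the only other value shown, and the whole of the present evidence is the limit of > 50000 nM in this assay, at which 2 of the 2 values shown sit. For the measured compounds named here, no pair of measured compounds differing in one place exists, so no step in this assay has been measured and nothing can be read about what a single change does here.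

Compound 3 `Cc1ccc(-n2nncc2CN2C(=O)C3(C(C#N)=C(N)Oc4c(N)cc5nc6ccccc6nc5c43)c3ccccc32)cc1Cl` is the next compound and differs from compound 2 in one place, (3-chloro-4-methylphenyl in place of 4-methoxyphenyl on an aromatic nitrogen), on an aromatic nitrogen of a five-membered aromatic ring with 3 nitrogen. Given that compound 2 sits at a limit, > 50000 nM, the change expected of this step, a number no higher from compound 2 to compound 3 (the limit leaves the size open), is none beyond the scatter. Compound 3 is thus expected to return about 50000 nM in this assay, within 20000 nM to 120000 nM, most likely again as a limit rather than a number.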

Compound 3, half-maximal inhibitory concentration: 11800 nM
Estimate against measurement, compound 3: 4.2-fold (0.63 log units) above, outside the stated range (below it).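

In this assay, the group on the aromatic nitrogen of the five-membered ring proves able to move the read-out, which the two limits alone could not show: 3-chloro-4-methylphenyl in place of 4-methoxyphenyl gives an at least 4.2-fold lower number from compound 2 to compound 3 (0.62 log units; beyond the scatter) on an otherwise unchanged structure. Compound 3 is thus the only compound shown that returns a number rather than a limit, and the shared core with its amino group is not by itself what keeps compound 2 out of the measurable range. On these data alone, the true size of the step stays unknown because compound 2 has only a limit and no number: the limit of > 50000 nM in this assay, at which 2 of the 3 values shown sit.

The change replaces methoxy with chloro and methyl in one move, so the step cannot be divided between the chlorine and the methyl, and 3-chlorophenyl or 4-methylphenyl alone would be needed to separate them. As far as these compounds go, whether a different kind of group on this ring, such as an amine or a carboxylic acid, would carry the number further also remains open, as does any reading of compound 1, which has no single-place link to compound 3.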